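From pyrrole to cyclopentene in a cytotoxicity read-out

This account rests on a few compounds, and the source may have more. Where it says the series, first, only, none or still open, it means among the compounds named here.

Three compounds around one shared core have entries in an ADME assay on Huh-7 cells (Homo sapiens) for cytotoxicity, with a stated time of 72 h (a lower number here means that less compound is tolerated, a higher number that more compound is tolerated), and none of them carries a plain number. For compound 1 `CC(C)CCn1nc(-c2cccs2)c(O)c(C2=NS(=O)(=O)c3cc(S(=O)(=O)N(C)C)ccc3N2)c1=O` the entry "not determined" (no result reported) stands alone. Compound 2 `CC(C)CCn1nc(-c2ccn(C)c2)c(O)c(C2=NS(=O)(=O)c3cc(NS(C)(=O)=O)ccc3N2)c1=O` gives > 1000 nM as a limit of the assay and not a number. Compound 3 `CS(=O)(=O)Nc1ccc2c(c1)S(=O)(=O)N=C(c1c(O)c(-c3ccc(Cl)s3)nn(CCC3CC3)c1=O)N2` gives > 33000 nM as a limit too. Compound 2 thus has no exact position, only that limit.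

Compound 4 `CC(C)CCn1nc(C2=CCCC2)c(O)c(C2=NS(=O)(=O)c3cc(NS(C)(=O)=O)ccc3N2)c1=O` differs from compound 2 in one group, with cyclopent-1-en-1-yl in place of 1-methyl-1H-pyrrol-3-yl on an aromatic carbon and nothing else changed. No measured step sizes such a swap. For the measured compounds named here, compound 3 is the only guide to how high the tolerated level may lie, with its limit of > 33000 nM as the sole reference in this assay for now. The estimated step that the limit leaves unreadable from compound 2 to compound 4 is upward and large, though it is counted from a limit. For compound 4 the estimated value is 20000 nM with an expected range from 4000 nM to 50000 nM. A limit of the assay in place of a plain number would be no surprise.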

Compound 4, half-maximal cytotoxic concentration: > 1000 nM
Compound 4: a limit, no number; the forecaster's own chance of this, stated with the estimate: 75%; the middle value lies beyond the limit too.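

No step can be read from compound 2 to compound 4, because both entries are the same limit and not numbers: the limit of > 1000 nM in this assay, at which 2 of the 4 values shown sit.

As far as these compounds go, whether cyclopent-1-en-1-yl in place of 1-methyl-1H-pyrrol-3-yl changes the tolerated concentration in this assay at all remains open.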